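Benzimidazole enone sulfonamide series: predicting compound 4

The compounds below may be only part of what the source reports. "The series", "measured", "known", "first", "only" and "open" are said of these compounds alone.

Measured in a functional assay on 143B cells (Homo sapiens) for antiproliferative activity, read by MTT assay, with a stated time of 48 h; on this read-out lower numbers stand for stronger inhibition and higher numbers for weaker inhibition:
- compound 1 `O=C(Nc1cccc(/C=C/C(=O)c2nc3ccccc3[nH]2)c1)c1ccccc1`: 8340 nM
- compound 2 `COc1cccc(C(=O)Nc2cccc(/C=C/C(=O)c3nc4ccccc4[nH]3)c2)c1`: 4610 nM
- compound 3 `O=C(/C=C/c1cccc(NS(=O)(=O)c2ccccc2Cl)c1)c1nc2ccccc2[nH]1`: 4790 nM

Compound 3 sits second highest of the three numbers, with compound 2 nearest (a 1.0-fold higher number from compound 2 to compound 3 (0.02 log units; within the scatter)) and compound 1 furthest (a 1.7-fold lower number from compound 1 to compound 3 (0.24 log units; within the scatter)); every gap in this set lies within the scatter, so no ranking among the three can be claimed.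

Compound 4 `O=C(/C=C/c1cccc(NS(=O)(=O)c2cc(Cl)cc(Cl)c2)c1)c1nc2ccccc2[nH]1` is not yet measured. Its change from compound 3 is 3,5-dichlorophenyl in place of 2-chlorophenyl on a sulfonyl sulfur. Within the data shown here, the steps that bear on it are those touching the same aryl attachment: the methoxy addition a 1.8-fold lower number from compound 1 to compound 2 (0.26 log units; within the scatter) and the two swaps of the whole group, a 1.7-fold lower number from compound 1 to compound 3 (0.24 log units; within the scatter) and a 1.0-fold higher number from compound 2 to compound 3 (0.02 log units; within the scatter). All three were within the scatter. Nothing here supports a step beyond the scatter in this assay for a change of chlorine pattern on the sulfonyl aryl, in either direction.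

Compound 4 is therefore expected near 4500 nM, with a range from 2000 nM to 10000 nM, meaning an estimated step of a 1.1-fold lower number from compound 3 to compound 4 (0.03 log units; within the scatter) from compound 3 to compound 4.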

Compound 4, half-maximal inhibitory concentration: 5950 nM
The estimate for compound 4 lay 1.3-fold (0.12 log units) below the measured number; the range from low to high includes it.
By their numbers in this assay, from the lowest: compounds 2, 3, 4 and 1 (each within the scatter of the next).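

In this assay, 3,5-dichlorophenyl in place of 2-chlorophenyl on a sulfonyl sulfur gives a 1.2-fold higher number from compound 3 to compound 4 (0.09 log units; within the scatter), the only step shown that changes the chlorine pattern on this aryl while keeping the sulfonamide link. Among these compounds, the earlier steps changed a methoxy on the benzoyl ring or swapped the whole group on the nitrogen, so this is the first direct reading at this position: a second chlorine and a different chlorine pattern produce no step beyond the scatter. No evidence on any property of these compounds bears on this result.

Whether any change on this aryl can move the number beyond the scatter remains open, as the sulfonyl aryl groups shown carry only chlorine. Going by these compounds, how a carboxylic acid or an amine on this aryl, or a longer alkyl chain in its place on the sulfonyl sulfur, would read is also open.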